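This account rests on a few compounds, and the source may have more. Where it says the series, first, only, none or still open, it means among the compounds named here.

The measured compounds:

Compound 1, `CCCCCC(=O)N(NC(=O)c1ccc(CC)cc1)C(C)(C)C`: 2820 nM
Compound 2, `CCCCCCC(=O)N(NC(=O)c1ccc(CC)cc1)C(C)(C)C`: 11700 nM
Compound 3, `CCCCC(=O)NN(C(=O)c1cc(C)cc(C)c1)C(C)(C)C`: 1860 nM

All three were tested in an assay on cells for agonist activity at ecdysone receptor (Bombyx mori), read by a luciferase reporter, with a stated time of 24 h; a higher number here means that more compound is needed for the effect, a lower number that less compound is needed. Compound 1 and compound 2 share one core and differ in one place: methyl in place of hydrogen on a saturated chain carbon, five bonds along the chain from a carbonyl carbon. This change gave a 4.1-fold higher number from compound 1 to compound 2 (0.62 log units; beyond the scatter), so the longer chain needed more compound for the same effect.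

Compound 3 carries a different core; the difference between the two cores is not broken down here. In this assay compound 3 gives 1860 nM, a number within the scatter of compound 1 but beyond it from compound 2.

Compound 4, `CCCCCC(=O)NN(C(=O)c1cc(C)cc(C)c1)C(C)(C)C`, has not yet been measured. It is made from compound 3 by the same kind of change as compound 2 from compound 1: methyl in place of hydrogen on a saturated chain carbon, four bonds along the chain from a carbonyl carbon. The place is not identical, though: in the earlier pair the entering methyl sits five bonds along the chain from a carbonyl carbon, here it sits four bonds along.

The expectation rests on compound 1 and compound 2, whose step was a 4.1-fold higher number from compound 1 to compound 2 (0.62 log units; beyond the scatter), and on the starting value of compound 3, 1860 nM. A rise of similar kind is expected, tempered for the different place and the different core, giving an estimated step of a 3.0-fold higher number from compound 3 to compound 4 (0.47 log units; beyond the scatter). Compound 4 is therefore expected to give about 5500 nM in this assay, with a likely range from 2500 nM to 14000 nM.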

Compound 4, half-maximal effective concentration: 79.4 nM
Beside the measured number, compound 4's estimate is 69-fold (1.84 log units) above it; the measured number lies below the stated range.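

In this assay the added methyl on the chain of compound 3 gave a 23-fold lower number from compound 3 to compound 4 (1.37 log units; beyond the scatter), so here the longer chain needed much less compound for the same effect. The same kind of change therefore went in opposite directions on the two cores, and the gap between the two steps is large: the same change on two cores in this assay, a 4.1-fold higher number (0.62 log units; beyond the scatter) from compound 1 to compound 2 and a 23-fold lower number (1.37 log units; beyond the scatter) from compound 3 to compound 4, 97-fold (1.99 log units) apart, beyond the scatter of two such steps. Going by these compounds alone, this shows that the step measured on the core of compound 1 cannot be carried over to the core of compound 3 in this series, neither in size nor in direction, but it does not show what lies behind the difference: the two pairs differ in their core and also in the place of the entering methyl, five bonds along the chain in one and four bonds along in the other, and with only one pair on each core these two differences cannot be told apart.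

The compounds shown leave open whether a longer chain on the core of compound 3 would keep lowering the number or would raise it again, as happened on the core of compound 1. They also leave open how that core would respond to a chain ending in a hydroxyl group or an amine instead of a methyl.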